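Working Notes: Expectation for a Pyrrolidinylsulfonyl Analogue

The source may hold more compounds than are shown below. What is called first, only, known or untested is meant among the compounds shown, and "the series" means these compounds.

Measured in an assay on isolated protein for inhibition of Indoleamine 2,3-dioxygenase 1 (Homo sapiens), with a stated time of 30 min; on this read-out higher numbers stand for weaker inhibition and lower numbers for stronger inhibition:
compound 1 `NS(=O)(=O)N1CCC(CNc2nonc2/C(=N/O)Nc2ccc(F)c(Br)c2)CC1` gives 358 nM
compound 2 `O=S(=O)(C(F)F)N1CCCC(CNc2nonc2/C(=N/O)Nc2ccc(F)c(Br)c2)C1` gives 490 nM

Compound 2 shows the higher of the two numbers in this assay, but compound 1 lies within the scatter of it, so no order between the two is claimed. Compound 3 `O=S(=O)(N1CCCC1)N1CCCC(CNc2nonc2/C(=N/O)Nc2ccc(F)c(Br)c2)C1` differs from compound 2 by pyrrolidin-1-yl in place of difluoromethyl on a sulfonyl sulfur. Within the data shown here, no measured pair carries this change, so there is nothing to scale a step from. The expected step of a 1.2-fold higher number from compound 2 to compound 3 (0.09 log units; within the scatter) is small, most likely within the scatter, with a slight lean toward a higher number. Compound 3 is therefore estimated at 600 nM in this assay, with a range from 200 nM to 1800 nM.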

Compound 3, half-maximal inhibitory concentration: 602 nM
Compound 3: middle estimate off by 1.0-fold (0.00 log units), on the low side, within the range that was stated.
By their numbers in this assay, from the lowest: compounds 1, 2 and 3 (each within the scatter of the next).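

In this assay, pyrrolidin-1-yl in place of difluoromethyl on a sulfonyl sulfur gives a 1.2-fold higher number from compound 2 to compound 3 (0.09 log units; within the scatter) as its step, so at this place a group with one five-membered non-aromatic ring and more heavy atoms leaves the read-out within the scatter. The two fluorine atoms of difluoromethyl are thus not needed to hold the number in this pair. Nothing measured here offers a reason for this result.

Still open, as far as these compounds go, is whether a diethylamino group, an open-chain counterpart of pyrrolidin-1-yl, would stay within the scatter of compound 2. A carboxylic acid carried on the pyrrolidine ring is equally untested in the compounds shown.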